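Swapping the Aryl Substituent for Cyclopropyl

This account rests on a few compounds, and the source may have more. Where it says the series, first, only, none or still open, it means among the compounds named here.

Going by the values given here, compound 2 `CCOC(=O)c1cnc(-c2ccc(Cl)s2)nc1NN1C(=O)C=C(C)C1=O` sits at the higher end of the two numbers measured so far: in a functional assay on Jurkat cells for inhibition of nuclear factor NF-kappa-B complex (Homo sapiens) (a lower number here means a stronger inhibitor, a higher number a weaker inhibitor), compound 2 gives 300 nM, while its nearest neighbour compound 1 `CCOC(=O)c1cnc(SC)nc1NN1C(=O)C=C(C)C1=O` gives 200 nM in this assay. Among the compounds with values here, the only measured step so far, a 1.5-fold higher number from compound 1 to compound 2 (0.18 log units; within the scatter), replaced methylsulfanyl with 5-chlorothiophen-2-yl on the aromatic carbon that lies between two ring nitrogen atoms, and the outcome stayed within the scatter.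

Compound 3 `CCOC(=O)c1cnc(C2CC2)nc1NN1C(=O)C=C(C)C1=O` continues from compound 2 with the change (cyclopropyl in place of 5-chlorothiophen-2-yl on an aromatic carbon), at the position between two ring nitrogen atoms and para to the ethoxycarbonyl group. Within the data shown here, no measured pair compares a cyclopropyl with an aryl group on this carbon, so the step from compound 1 to compound 2 is the only guide, and it showed that this position tolerated a substantial change without moving the number beyond the scatter. On that basis the step of a 1.2-fold lower number from compound 2 to compound 3 (0.08 log units; within the scatter) is expected to stay small. Compound 3 is therefore estimated at 250 nM in this assay, with a range from 90 nM to 700 nM.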

Compound 3, half-maximal inhibitory concentration: 1000 nM
For compound 3 the middle estimate is 4.0-fold (0.60 log units) below the measured one; measured number above the stated range.
By their numbers in this assay, from the lowest: compounds 1 and 2 (each within the scatter of the next); then compound 3.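

In this assay this position turns out not to be indifferent to its substituent: the step of a 3.3-fold higher number from compound 2 to compound 3 (0.52 log units; beyond the scatter) and the step of a 5.0-fold higher number from compound 1 to compound 3 (0.70 log units; beyond the scatter) both lie beyond the scatter, unlike the earlier step of a 1.5-fold higher number from compound 1 to compound 2 (0.18 log units; within the scatter) between the other two groups. Methylsulfanyl and 5-chlorothiophen-2-yl therefore cannot be told apart on this carbon, while cyclopropyl gives a weaker inhibitor than either, so the earlier tolerance does not extend to every group placed here. Nothing available gives a reason for this weakening, whether for the departure of a five-membered aromatic ring or for the arrival of a three-membered non-aromatic ring of carbon only.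

The three compounds leave open whether the weakening is particular to cyclopropyl or would also follow with other non-aromatic groups on this carbon, such as an isopropyl group, a longer chain like n-butyl, or an amine like dimethylamino. They also leave open how a phenyl ring would compare here, and whether a carboxylic acid in place of the ethoxycarbonyl group would alter the picture.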